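The compounds below may be only part of what the source reports. "The series", "measured", "known", "first", "only" and "open" are said of these compounds alone.

Compound 1 `C=C1[C@@H](OC(C)=O)C[C@@H]2[C@](C)(CO[Si](C)(C)C(C)(C)C)[C@H](OC(C)=O)CC[C@@]2(C)[C@@H]1C[C@@H](Nc1ccc(OC)c(OC)c1)C1=CCOC1=O` serves as the reference point of this set. In a functional assay on KB cells (Homo sapiens) for cytotoxicity, read by sulforhodamine B assay (on this read-out lower numbers stand for stronger inhibition and higher numbers for weaker inhibition), compound 1 gives 5800 nM, the lowest of the two numbers shown. Compound 2 `C=C1[C@@H](OC(C)=O)C[C@@H]2[C@](C)(COC=O)[C@H](OC(C)=O)CC[C@@]2(C)[C@@H]1C[C@@H](Nc1ccccc1)C1=CCOC1=O`, which carries a formate in place of the silyl ether and an unsubstituted phenyl on the amine nitrogen, gives 32100 nM in this assay. Compound 3 `C=C1[C@@H](OC(C)=O)C[C@@H]2[C@](C)(COC=O)[C@H](OC(C)=O)CC[C@@]2(C)[C@@H]1C[C@@H](Nc1ccc(OC)c(OC)c1)C1=CCOC1=O` reaches only a limit of this assay, > 50000 nM. Two steps between these compounds have been measured: an at least 8.6-fold higher number from compound 1 to compound 3 (0.93 log units; beyond the scatter), and an at least 1.5-fold higher number from compound 2 to compound 3 (0.19 log units; that floor lies within the scatter). Compound 4 `C=C1[C@@H](OC(C)=O)C[C@@H]2[C@](C)(CO[Si](C)(C)C(C)(C)C)[C@H](OC(C)=O)CC[C@@]2(C)[C@@H]1C[C@@H](Nc1cccc(OC)c1)C1=CCOC1=O` keeps the silyl ether of compound 1 and differs from it by hydrogen in place of methoxy on an aromatic carbon. Neither measured step covers this change directly; the nearest is the step from phenyl to 3,4-dimethoxyphenyl, whose floor lies within the scatter, so the removal of one methoxy is expected to leave the number close to where compound 1 stands, with no step beyond the scatter in either direction. Compound 4 is therefore expected to give 5000 nM, between 2000 nM and 13000 nM, which corresponds to a 1.2-fold lower number from compound 1 to compound 4 (0.06 log units; within the scatter).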

Compound 4, half-maximal inhibitory concentration: 45200 nM
Compound 4: middle estimate off by 9.0-fold (0.96 log units), on the low side; measured number above the stated range.
By their numbers in this assay, from the lowest: compound 1; then compounds 2 and 4 (each within the scatter of the next). At a limit, above all of these: compound 3.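

In this assay, going from 3,4-dimethoxyphenyl to 3-methoxyphenyl on the amine nitrogen, with the silyl ether kept, gives a 7.8-fold higher number from compound 1 to compound 4 (0.89 log units; beyond the scatter). This shows that the methoxy on this aromatic carbon, para to a large group, counts on its own in this series. The earlier step on the aryl group, an at least 1.5-fold higher number from compound 2 to compound 3 (0.19 log units; that floor lies within the scatter), added both methoxy groups at once, with the formate in place, and ended at a limit of the assay, so it could not show this. Nothing given here bears on the cause of the new step.

From the compounds shown here alone, it remains open whether a hydroxyl, an ethoxy or a fluorine on this carbon would hold the number near that of compound 1. Going by these compounds, a 4-methoxyphenyl on the amine nitrogen, which would test the other methoxy, also remains open.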